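The compounds below may be only part of what the source reports. "The series", "measured", "known", "first", "only" and "open" are said of these compounds alone.

Measured compounds:

Compound 1, `CC[C@H](C)[C@H](N)CN(C(=O)[C@@H]1C[C@H]1c1cc(F)cc(F)c1)c1ccc(-c2ccccc2)cc1`: in a functional assay for agonist activity at G protein-coupled receptor 88 (Homo sapiens), read by HTRF and cAMP accumulation (a lower number here means that less compound is needed, a higher number that more compound is needed for the effect), compound 1 gives 960 nM.
Compound 2, `CC[C@H](C)[C@H](N)CN(C(=O)[C@@H]1C[C@H]1c1ccc(F)cc1F)c1ccc(-c2ccccc2)cc1`: in this assay compound 2 gives 1300 nM.
Compound 3, `CC[C@H](C)[C@H](N)CN(C(=O)[C@@H]1C[C@H]1c1ccsc1)c1ccc(-c2ccccc2)cc1`: in this assay compound 3 gives 450 nM.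

All three share one core and differ only in the aromatic group on the saturated ring carbon of the three-membered ring. Compound 3 holds the lowest number of the three: the step from compound 1 is a 2.1-fold lower number from compound 1 to compound 3 (0.33 log units; beyond the scatter), and that from compound 2 is a 2.9-fold lower number from compound 2 to compound 3 (0.46 log units; beyond the scatter), both beyond the scatter. Between the two difluorophenyl variants the step is a 1.4-fold higher number from compound 1 to compound 2 (0.13 log units; within the scatter), within the scatter.

Compound 4, `CC[C@H](C)[C@H](N)CN(C(=O)[C@@H]1C[C@H]1c1ncc(C)s1)c1ccc(-c2ccccc2)cc1`, has not yet been measured. It differs from compound 3 by 5-methyl-1,3-thiazol-2-yl in place of thiophen-3-yl on a saturated ring carbon. The measured steps that bear on it are those in which the aromatic group alone was exchanged; they moved this assay by modest amounts in either direction. An exchange of one five-membered heteroaromatic ring for another is therefore expected to move the number only modestly, and the direction cannot be called from the three compounds shown. For compound 4 the step from compound 3 is expected to be a 1.3-fold higher number from compound 3 to compound 4 (0.12 log units; within the scatter). Compound 4 is accordingly estimated at 600 nM, with a range from 250 nM to 1500 nM.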

Compound 4, half-maximal effective concentration: 1300 nM
Beside the measured number, compound 4's estimate is 2.2-fold (0.34 log units) below it, within the range that was stated.
By their numbers in this assay, from the lowest: compound 3; then compounds 1, 2 and 4 (each within the scatter of the next).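

In this assay, the exchange on this saturated ring carbon of the three-membered ring gives a 2.9-fold higher number from compound 3 to compound 4 (0.46 log units; beyond the scatter) and removes the lead that thiophen-3-yl held, so among the compounds shown a five-membered aromatic ring does not by itself go with the lowest number at this position. Measured against the two difluorophenyl variants, 5-methyl-1,3-thiazol-2-yl gives no change at the digits printed from compound 2 to compound 4 (within the scatter) and a 1.4-fold higher number from compound 1 to compound 4 (0.13 log units; within the scatter), which places this heteroaromatic group level with both six-membered aryl groups and leaves compound 3 alone in holding a lower number than the others. No independent measurement shown here bears on what lies behind this step.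

The change brings in a ring nitrogen and a methyl group together, so the compounds shown cannot assign the step to either one, and a plain 1,3-thiazol-2-yl group, or a 5-methylthiophen-3-yl group, would be needed to divide it. Also open, as far as these compounds go, is whether the lower number of compound 3 depends on the sulfur-containing ring in particular, a question that a furan-3-yl group at the same carbon could address.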